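Methyl in Place of Chloro on the Fused Core

A few compounds are considered here, and "the series" means these few. Any claim that something is new, unique, unknown or untested is made for them only; others in the source may bear on it.

Compound 2 `O=c1oc(Nc2ccccc2I)nc2ccc(Cl)cc12` is the chloro analogue of compound 1 `O=c1oc(Nc2ccccc2I)nc2ccccc12`; in an assay on isolated protein for inhibition of complement C1r subcomponent (Homo sapiens) (a higher number here means a weaker inhibitor, a lower number a stronger inhibitor), compound 2 gives 4000 nM, and its number sits alongside that of compound 1, which in this assay gives 3500 nM. For the measured compounds named here, the only measured step that bears on the next change is a 1.1-fold higher number from compound 1 to compound 2 (0.06 log units; within the scatter). Compound 3 `Cc1ccc2nc(Nc3ccccc3I)oc(=O)c2c1` differs from compound 2 in one place: methyl in place of chloro on an aromatic carbon. Because a 1.1-fold higher number from compound 1 to compound 2 (0.06 log units; within the scatter) stayed within the scatter, no movement beyond the scatter is expected here, so compound 3 is expected to show a 1.1-fold lower number from compound 2 to compound 3 (0.02 log units; within the scatter). Compound 3 is therefore estimated at 3800 nM, between 1500 nM and 9500 nM.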

Compound 3, half-maximal inhibitory concentration: > 62500 nM
Compound 3 gave a limit, no number (the forecaster's own chance of this, stated with the estimate: 5%); middle value at least 16-fold (1.21 log units) from the limit.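

In this assay compound 3 stands only as a limit: the limit of > 62500 nM in this assay, at which 1 of the 3 values shown sits.

This aromatic carbon is not indifferent to what it carries: chloro in place of hydrogen stayed within the scatter, whereas methyl in place of chloro gives an at least 15-fold higher number from compound 2 to compound 3 (1.19 log units; beyond the scatter), and methyl in place of hydrogen gives an at least 17-fold higher number from compound 1 to compound 3 (1.25 log units; beyond the scatter). Chloro and methyl match in heavy-atom count and in hydrogen-bond donors and acceptors, so those counts do not separate them here.

Going by these compounds, whether an ethyl, a methoxy or an amine on this carbon would behave like methyl or like chloro stays open. Also open, on these data alone, is whether methyl elsewhere on the shared core gives the same result.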